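Aryl versus alkyl amines on the shared core

The source may report more compounds than this note shows. Statements on the series, on what has been measured and on what is new or still open speak of the compounds shown alone.

In a functional assay on HeLa cells (Homo sapiens) for inhibition, read by sulforhodamine B assay (a higher number here means a weaker inhibitor, a lower number a stronger inhibitor), compound 1 `Cc1ccc(NC2=CC(=O)c3c(nc4n3[C@H]3OC[C@@H](O)[C@H]3OC4)C2=O)cc1C` gives 4320 nM. Compound 2 `O=C1C(NC2CCCC2)=CC(=O)c2c1nc1n2[C@H]2OC[C@@H](O)[C@H]2OC1` returns only a limit in this assay, > 16000 nM. Compound 3 `CCCN(CCC)C1=CC(=O)c2c(nc3n2[C@H]2OC[C@@H](O)[C@H]2OC3)C1=O` likewise sits at a limit in this assay, > 16000 nM. Compound 3 thus stands at the weak end of the numbers shown, a limit rather than a value, as noted under (the limit of > 16000 nM in this assay, at which 2 of the 3 values shown sit). The step of an at least 3.7-fold higher number from compound 1 to compound 3 (0.56 log units; beyond the scatter) swapped an arylamino for a dialkylamino group and was read as a loss; the step of an at least 3.7-fold higher number from compound 1 to compound 2 (0.56 log units; beyond the scatter) was a loss of the same order. The step that the two limits leave unreadable from compound 2 to compound 3 gives no readable size.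

Compound 4 `O=C1C(Nc2cccc(F)c2)=CC(=O)c2c1nc1n2[C@H]2OC[C@@H](O)[C@H]2OC1` carries the change ((3-fluorophenyl)amino in place of dipropylamino on a double-bonded ring carbon). This runs opposite to an at least 3.7-fold higher number from compound 1 to compound 3 (0.56 log units; beyond the scatter), an arylamino group replacing the dialkylamino group, so a lower number is expected, of roughly that size, though compound 1 is the only arylamino example shown. Compound 4 is expected to give 6000 nM, within 2500 nM to 16000 nM; the expected step is an at least 2.6-fold lower number from compound 3 to compound 4 (0.42 log units; beyond the scatter). A limit remains possible.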

Compound 4, half-maximal inhibitory concentration: > 8000 nM
Compound 4 was reported as a limit (the forecaster's own chance of this, stated with the estimate: 25%); at least 1.3-fold (0.12 log units) between middle value and limit.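

In this assay compound 4 gives only a limit, so a second arylamino group on this double-bonded ring carbon yields no measured value: the limit of > 8000 nM in this assay, at which 1 of the 4 values shown sits. Within the data shown here, compound 1 therefore remains the only compound here with a value rather than a limit, and 3-fluorophenyl in place of 3,4-dimethylphenyl on the amine nitrogen gives an at least 1.8-fold higher number from compound 1 to compound 4 (0.26 log units; that floor lies within the scatter), a floor that does not separate the two aryl groups. The steps among compound 2, compound 3 and compound 4 cannot be read, so any gain of arylamino over alkylamino groups rests on compound 1 alone, and compound 4 does not confirm it.

From the compounds shown here alone, it remains open whether the activity of compound 1 depends on its two methyl groups or extends to arylamino groups generally. A benzylamino or 4-methoxyphenylamino group on the same carbon could help settle this, provided it gives a value rather than a limit.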